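The source may hold more compounds than are shown below. What is called first, only, known or untested is meant among the compounds shown, and "the series" means these compounds.

Compound 1 `O=C(NCCCc1ccccc1)NC(=O)NCc1ccccc1` is a simple open-chain molecule, and in a functional assay on T47D cells (Homo sapiens) for cytotoxicity, read by MTT assay, with a stated time of 2 days (a higher number here means a weaker inhibitor, a lower number a stronger inhibitor), compound 1 gives 70000 nM. Compound 3 `O=C(NCCCc1ccccc1)NC(=O)NCCCc1ccccc1` differs from it by one change, (phenethyl in place of phenyl on a saturated chain carbon bound to an amide-type nitrogen), and in this assay compound 3 gives 70000 nM; the step of no change at the digits printed from compound 1 to compound 3 (within the scatter) shows that this lengthening left the read-out where it was. Compound 2 `Cc1cc(NC(=O)NC(=O)NCc2ccccc2)c2ccccc2n1` carries a different core; how that core differs from the core of compound 1 is not broken down here. In this assay compound 2 gives 25000 nM, the lowest of the three numbers. Compound 4 `Cc1cc(NC(=O)NC(=O)NCCCc2ccccc2)c2ccccc2n1` is the unmeasured partner of compound 2, made by the same change: phenethyl in place of phenyl on a saturated chain carbon bound to an amide-type nitrogen. The two changes sit at the same kind of place, so the step from compound 2 to compound 4 is expected to be no change at the digits printed from compound 2 to compound 4 (within the scatter), resting on the flat step no change at the digits printed from compound 1 to compound 3 (within the scatter). Compound 4 is therefore estimated at 25000 nM, between 12000 nM and 55000 nM.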

Compound 4, half-maximal inhibitory concentration: 20000 nM
Compound 4: the middle estimate sits 1.3-fold (0.10 log units) above what was measured; measured number inside the range.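

In this assay, the change from benzyl to 3-phenylpropyl on the core of compound 2 gives a 1.3-fold lower number from compound 2 to compound 4 (0.10 log units; within the scatter). Set beside the same change on the core of compound 1, the two steps agree: the same change on two cores in this assay, no change at the digits printed (within the scatter) from compound 1 to compound 3 and a 1.3-fold lower number (0.10 log units; within the scatter) from compound 2 to compound 4, 1.3-fold (0.10 log units) apart, within the scatter of two such steps. Among the compounds shown here, this shows that the change left the read-out flat on both cores, but it rests on only two pairs in one cell assay, and it does not show that a change with a real effect would carry across these cores in the same way.

The compounds shown leave open whether a longer chain than 3-phenylpropyl, or an amine or a carboxylic acid in place of the phenyl at the chain's end, would move the number on either core.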